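Hexyl to Isopropyl on Compound 2

A few compounds are considered here, and "the series" means these few. Any claim that something is new, unique, unknown or untested is made for them only; others in the source may bear on it.

Compound 1 `CCCCCCC(C#CC(=O)O)O/C=C/C(=O)OC`: > 100000 nM
Compound 2 `CCCCCCC(C#CC(=O)OC)O/C=C/C(=O)OC`: 2500 nM
Compound 3 `CCCCCCCCCCC(C#CC(=O)OC)O/C=C/C(=O)OC`: 2200 nM

In a functional assay on HBL-100 cells (Homo sapiens) for antiproliferative activity, read by sulforhodamine B assay, with a stated time of 48 h (on this read-out lower numbers stand for stronger inhibition of growth and higher numbers for weaker inhibition of growth), compound 2 gives 2500 nM, which lies within the scatter of the number for compound 3. The entry for compound 1 is a limit and not a number.

Compound 4 `COC(=O)C#CC(O/C=C/C(=O)OC)C(C)C` has not yet been measured. It departs from compound 2 by isopropyl in place of hexyl on a saturated chain carbon bound to an oxygen on an unsaturated carbon and a triple-bonded carbon. The large step of an at least 40-fold lower number from compound 1 to compound 2 (1.60 log units; beyond the scatter) lies elsewhere in the molecule and does not bear on this change. Within the data shown here, the one step that alters this chain is a 1.1-fold lower number from compound 2 to compound 3 (0.06 log units; within the scatter), and it lengthens the chain rather than shortening it. Among the measured compounds shown here, no measured compound carries a chain shorter than hexyl, so the expectation is uncertain. On that single step, no change beyond the scatter is expected in this assay, with a slight lean towards a higher number. The expected step is a 1.6-fold higher number from compound 2 to compound 4 (0.20 log units; within the scatter). Compound 4 is estimated at 4000 nM, with an expected range of 1500 nM to 15000 nM.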

Compound 4, concentration for 50% growth inhibition: 450 nM
Compound 4: the middle estimate sits 8.9-fold (0.95 log units) above what was measured; the whole stated range lies above it.
By their numbers in this assay, from the lowest: compound 4; then compounds 3 and 2 (each within the scatter of the next). At a limit, above all of these: compound 1.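

In this assay the change from hexyl to isopropyl on the saturated chain carbon bound to an oxygen on an unsaturated carbon and a triple-bonded carbon gives a 5.6-fold lower number from compound 2 to compound 4 (0.74 log units; beyond the scatter) and so shows that the number responds to the group at this place. Among these compounds, the only earlier change to this chain, butyl in place of hydrogen, gave a 1.1-fold lower number from compound 2 to compound 3 (0.06 log units; within the scatter) and showed no such response, so it is the shorter isopropyl group that first moves the number beyond the scatter. Nothing given here on these compounds offers a reason for this step.

The compounds shown leave open whether the lower number follows from the shorter chain or from its branching, which a straight propyl chain at this place would separate. They also leave open how far the effect extends, since a methyl or a cyclopropyl group on this carbon lies outside them.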